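The source may report more compounds than this note shows. Statements on the series, on what has been measured and on what is new or still open speak of the compounds shown alone.

Among the compounds with values here, compound 1 `ClCc1ccccc1Cn1cnc2c(Cl)nc(Cl)nc21` is one of only two compounds measured in a functional assay on SNB-75 cells (Homo sapiens) for cytotoxicity, read by sulforhodamine B assay, with a stated time of 48 h (a lower number here means a stronger inhibitor of growth, a higher number a weaker inhibitor of growth), where compound 1 gives 1540 nM. Its companion, compound 2 `ClCc1cccc(Cn2cnc3ncnc(Cl)c32)c1`, gives 1860 nM in this assay; the two numbers sit within the scatter of each other, so neither can be called the stronger inhibitor of growth, although the number of compound 1 is the lower of the two. The unmeasured compound 3 `Nc1nc(Cl)c2ncn(Cc3ccccc3CCl)c2n1` differs from compound 1 in a single place: amino in place of chloro on an aromatic carbon. Within the data shown here, no measured pair in this small set shows this exchange, so its effect has no direct precedent here, and the shared core of compound 1 is otherwise unchanged. Compound 3 is therefore expected to behave much like compound 1, with at most a modest step of a 1.6-fold higher number from compound 1 to compound 3 (0.21 log units; within the scatter) toward a weaker inhibitor of growth. The estimate for compound 3 in this assay is 2500 nM, within a range from 900 nM to 7000 nM.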

Compound 3, concentration for 50% growth inhibition: 8130 nM
Compound 3: the middle estimate sits 3.3-fold (0.51 log units) below what was measured; measured number outside the range, above it.
By their numbers in this assay, from the lowest: compounds 1 and 2 (each within the scatter of the next); then compound 3.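

In this assay, within the data shown here, the exchange of chloro for amino on the aromatic carbon between two ring nitrogen atoms gives a 5.3-fold higher number from compound 1 to compound 3 (0.72 log units; beyond the scatter), the first step in this set that lies beyond the scatter. This position is therefore not indifferent to what it carries: with the rest of the shared core unchanged, amino here goes with a weaker inhibitor of growth than chloro, although the step is modest. Nothing in the data shown accounts for the step.

This one pair cannot separate the effect of removing chloro from that of adding amino. As far as these compounds go, a methyl, methoxy or methylamino group on the same carbon would be needed to tell these apart, and whether the exchange has the same effect with the chloromethyl group placed elsewhere also remains open.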